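Benzamidomethyl for phenyl in the series

This account rests on a few compounds, and the source may have more. Where it says the series, first, only, none or still open, it means among the compounds named here.

Measured in a functional assay on A-431 cells (Homo sapiens) for inhibition, read by MTT assay, with a stated time of 72 h (a higher number here means a weaker inhibitor, a lower number a stronger inhibitor), as follows
compound 1 `Cc1ccc(-c2nnc(SCCCN3CCN(c4nc5ccccc5s4)CC3)o2)cc1` gives 61600 nM
compound 2 `c1ccc(-c2nnc(SCCCN3CCN(c4nc5ccccc5s4)CC3)o2)cc1` gives 93400 nM

Only these two values exist, and they sit together. Among the compounds with values here, the single measured step bearing on the next change is a 1.5-fold higher number from compound 1 to compound 2 (0.18 log units; within the scatter) with hydrogen in place of methyl on an aromatic carbon. Compound 3 `O=C(NCc1nnc(SCCCN2CCN(c3nc4ccccc4s3)CC2)o1)c1ccccc1` differs from compound 2 by benzamidomethyl in place of phenyl on an aromatic carbon on the shared core. The phenyl stays in place across the measured step, so that step gives no size or direction for this change. No shift beyond the scatter is expected, though with wide uncertainty, and compound 3 is expected to stay near compound 2 at 93400 nM in this assay on this reading. The expected move is a 1.2-fold lower number from compound 2 to compound 3 (0.10 log units; within the scatter) with no firm direction. In this assay the estimated value for compound 3 is 75000 nM with an expected range from 25000 nM to 200000 nM as the likely span.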

Compound 3, half-maximal inhibitory concentration: 55900 nM
Compound 3: the middle estimate sits 1.3-fold (0.13 log units) above what was measured, within the range that was stated.
By their numbers in this assay, from the lowest: compounds 3, 1 and 2 (each within the scatter of the next).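

In this assay, the aromatic carbon that bears phenyl in compound 2 also takes benzamidomethyl, a larger group with a hydrogen-bond donor and a hydrogen-bond acceptor that phenyl lacks, and the result is a 1.7-fold lower number from compound 2 to compound 3 (0.22 log units; within the scatter). Set against the methyl-bearing compound, the same replacement gives a 1.1-fold lower number from compound 1 to compound 3 (0.04 log units; within the scatter), so the three compounds remain together and this position has not yet shown any group that separates from the others beyond the scatter. No measured property or other supporting data bears on why the numbers stay together.

Going by these compounds, it remains open whether any substituent at this position can move the number beyond the scatter. An aminomethyl group, a carboxylic acid or a longer chain linking the amide to the ring would probe this, and the amide hydrogen's part in the result is also unresolved.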